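The compounds below may be only part of what the source reports. "The series", "measured", "known", "first", "only" and "open" are said of these compounds alone.

Measured in a functional assay on HOS-TE85 cells (Homo sapiens) for inhibition, read by CCK-8 assay, with a stated time of 72 h; on this read-out higher numbers stand for weaker inhibition and lower numbers for stronger inhibition:
- Compound 1 `COc1ccccc1N1C(=O)CSC1c1cccc(C(=O)NCCCCc2ccc(Cl)cc2)c1`: 78.6 nM
- Compound 2 `COc1ccccc1N1C(=O)CSC1c1cccc(C(=O)NCCCCn2cncn2)c1`: > 1000 nM, a limit of the assay and not a number
- Compound 3 `COc1ccccc1N1C(=O)CSC1c1cccc(C(=O)NCCCCn2cccn2)c1`: 91.7 nM

On this assay, compound 3 cannot be told apart from compound 1: the gap, a 1.2-fold higher number from compound 1 to compound 3 (0.07 log units; within the scatter), lies within the scatter. Compound 4 `COc1ccccc1N1C(=O)CSC1c1cccc(C(=O)NCCCCc2cccs2)c1` is still unmeasured. It carries thiophen-2-yl in place of 1H-pyrazol-1-yl on a saturated chain carbon, four bonds along the chain from an amide-type nitrogen.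

Within the data shown here, three measured steps concern this same place. Two involve compound 2 and are large: an at least 12-fold higher number from compound 1 to compound 2 (1.10 log units; beyond the scatter) and an at least 10-fold lower number from compound 2 to compound 3 (1.03 log units; beyond the scatter). Compound 2 therefore goes against any idea that every aromatic ring end holds the value, while the 4-chlorophenyl and 1H-pyrazol-1-yl ends of the other two compounds match. Thiophen-2-yl is not the 1H-1,2,4-triazol-1-yl of compound 2, so no step beyond the scatter is expected, in either direction. The expected change is a 1.1-fold lower number from compound 3 to compound 4 (0.06 log units; within the scatter). For compound 4 the estimated value is 80 nM, with an expected range from 30 nM to 220 nM.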

Compound 4, half-maximal inhibitory concentration: 46 nM
The estimate for compound 4 lay 1.7-fold (0.24 log units) above the measured number, within the range that was stated.
By their numbers in this assay, from the lowest: compounds 4, 1 and 3 (each within the scatter of the next). At a limit, above all of these: compound 2.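

At this place on the chain, a further ring end now matches the others, and it holds only carbon and sulfur, so a ring nitrogen is not needed to keep the value: the thiophen-2-yl group gives a 2.0-fold lower number from compound 3 to compound 4 (0.30 log units; within the scatter) and a 1.7-fold lower number from compound 1 to compound 4 (0.23 log units; within the scatter). Only compound 2 goes against the idea that an aromatic ring end here holds the value, and the new compound sets it further apart, with an at least 21-fold lower number from compound 2 to compound 4 (1.33 log units; beyond the scatter). The value of compound 2 is a limit of the assay and not a number: the limit of > 1000 nM in this assay, at which 1 of the 4 values shown sits.

Nothing here tells how an amine or a carboxylic acid at the end of the chain would compare with these ring ends. On these data alone, it also stays open whether a longer chain would carry the thiophen-2-yl group equally well.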